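The compounds below may be only part of what the source reports. "The series", "measured", "known", "first", "only" and "open" are said of these compounds alone.

Going by the values given here, in a functional assay on PANC-1 cells (Homo sapiens) for cytotoxicity, read by WST assay, with a stated time of 24 h (a lower number here means a stronger inhibitor, a higher number a weaker inhibitor), compound 3 (`O=C(CCCCCCCCc1ccc(F)cc1)N1CCCCC1`) gives 99800 nM as the only true number so far. Compound 1 (`N#Cc1ccc(CCCCCCCCC(=O)N2CCCCC2)cc1`) gives > 100000 nM as its reading, which is a limit and not a number. Compound 2 (`O=C(CCCCCCCCc1ccc(O)cc1)N1CCCCC1`) gives > 100000 nM as its reading, which is also a limit. That limit (the limit of > 100000 nM in this assay, at which 2 of the 3 values shown sit) is shared by compound 1 and compound 2.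

Compound 4 (`O=C(CCCCCCCCc1cccc(Cl)c1)N1CCCCC1`) carries 3-chlorophenyl in place of 4-fluorophenyl on a saturated chain carbon, eight bonds along the chain from a carbonyl carbon. Two measured steps also change the group on the aromatic ring: fluoro in place of cyano (a number no higher from compound 1 to compound 3 (the limit leaves the size open)) and fluoro in place of hydroxy (a number no higher from compound 2 to compound 3 (the limit leaves the size open)). Neither has a readable size, so neither points to a large effect or a direction.

The expectation therefore rests on compound 3 and its reading of 99800 nM with no step beyond the scatter expected in either direction. The expected change is small (a 1.2-fold lower number from compound 3 to compound 4 (0.10 log units; within the scatter)) in this estimate. Compound 4 is estimated at 80000 nM with an expected range from 40000 nM to 100000 nM overall.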

Compound 4, half-maximal inhibitory concentration: > 100000 nM
Compound 4: only a limit was reported; the forecaster's own chance of this, stated with the estimate: 40%; middle value at least 1.2-fold (0.09 log units) from the limit.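

Placing 3-chlorophenyl in the spot held by 4-fluorophenyl, on a saturated chain carbon, eight bonds along the chain from a carbonyl carbon, gives a number no lower from compound 3 to compound 4 (the limit leaves the size open) in this assay, so this change brings no measurable gain in strength. The steps from compound 1 and compound 2 to compound 4 cannot be read, as both ends of each are limits. Compound 4 adds a third reading at the same limit of the assay: the limit of > 100000 nM in this assay, at which 3 of the 4 values shown sit.

The change swaps the halogen and moves it on the ring in one step, so the compounds shown cannot separate those two changes. Going by these compounds, whether an amine or a carboxylic acid on the ring, or a longer chain, would bring the reading clearly below this limit remains open.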